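Swapping Methyl for Dimethylamino: Expected Solubility of Compound 4

The source may hold more compounds than are shown below. What is called first, only, known or untested is meant among the compounds shown, and "the series" means these compounds.

Three compounds have been measured in a physicochemical assay for solubility, read by HPLC, in phosphate buffer, with a stated time of 24 h, at pH 7.4; on this read-out lower numbers stand for lower solubility and higher numbers for higher solubility:

Compound 1 `CCCS(=O)(=O)Nc1ccc(Cl)c(C(=O)Nc2cnc3[nH]nc(OC)c3c2)c1F`: 2 ug/mL
Compound 2 `CCCS(=O)(=O)Nc1ccc(F)c(C(=O)Nc2cnc3[nH]ncc3c2)c1F`: 150 ug/mL
Compound 3 `CCCS(=O)(=O)Nc1ccc(F)c(C(=O)Nc2cnc3[nH]nc(C)c3c2)c1F`: 740 ug/mL

Compound 3 gives the highest number of the three. For the measured compounds named here, its nearest neighbour is compound 2, and the only single-point step among the measured compounds is a 4.9-fold higher number from compound 2 to compound 3 (0.69 log units; beyond the scatter), where the methyl replaces a hydrogen on the same aromatic carbon. Compound 1 differs from compound 3 in two places. In this assay compound 1 gives 2 ug/mL, far below compound 3.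

Compound 4 `CCCS(=O)(=O)Nc1ccc(F)c(C(=O)Nc2cnc3[nH]nc(N(C)C)c3c2)c1F` is not yet measured. It differs from compound 3 by dimethylamino in place of methyl on an aromatic carbon. The step from compound 2 to compound 3 bears on this position, since it shows that a small group there moved the number in this assay by a modest but real amount. Going by the values given here, no measured step, however, shows what a dimethylamino group does at this site, so the direction is open. The expected step of a 1.2-fold lower number from compound 3 to compound 4 (0.09 log units; within the scatter) is therefore small, most likely within the scatter, with a wide range on either side. For compound 4 the estimate in this assay is 600 ug/mL, with a range from 150 ug/mL to 2000 ug/mL.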

Compound 4, solubility: 450 ug/mL
For compound 4 the middle estimate is 1.3-fold (0.12 log units) above the measured one; the range from low to high includes it.
By their numbers in this assay, from the lowest: compound 1; then compound 2; then compounds 4 and 3 (each within the scatter of the next).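

In this assay, the change to dimethylamino on this aromatic carbon gives a 1.6-fold lower number from compound 3 to compound 4 (0.22 log units; within the scatter) and so stays within the usual scatter, which means compound 3 and compound 4 cannot be told apart on this read-out even though the entering group brings in a nitrogen and a hydrogen-bond acceptor. Set against hydrogen at the same carbon, the change gives a 3.0-fold higher number from compound 2 to compound 4 (0.48 log units; beyond the scatter) and lies beyond the scatter, so this site now has two groups, methyl and dimethylamino, that each give a higher number than hydrogen, where before there was only a 4.9-fold higher number from compound 2 to compound 3 (0.69 log units; beyond the scatter) to go on. Nothing measured here says why the number behaves this way at this position.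

The compounds shown leave open whether the same holds for other groups on this carbon, such as a carboxylic acid or a longer alkyl chain. Methoxy at this site appears only in compound 1, which also differs from the others in a second place, so what methoxy alone does on this carbon stays unknown.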